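This account rests on a few compounds, and the source may have more. Where it says the series, first, only, none or still open, it means among the compounds named here.

Of the compounds shown here, three built on one shared core have been tested in a functional assay on MOLT-4 cells (Homo sapiens) for inhibition, read by sulforhodamine B assay, with a stated time of 48 h, tested at 10 uM; on this read-out higher numbers stand for more inhibition at the one concentration tested (going by the name of the read-out) and lower numbers for less inhibition. Compound 1 `Brc1cn2ccnc2c(-c2ccc3ncn(C4CCCCC4)c3c2)n1` gives 26.3%. Compound 2 `c1ccc2c(-c3cn4ccnc4c(-c4ccc5ncn(C6CCCCC6)c5c4)n3)cccc2c1` gives 44.7%, and compound 3 `Fc1ccc(-c2cn3ccnc3c(-c3ccc4ncn(C5CCCCC5)c4c3)n2)cc1` gives 25.2%. On these numbers compound 1 stands second highest of the three: its gap to compound 3 lies within the scatter, while compound 2 sits above it beyond the scatter.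

Compound 4 `Fc1ccccc1-c1cn2ccnc2c(-c2ccc3ncn(C4CCCCC4)c3c2)n1` differs from compound 1 in a single place: 2-fluorophenyl in place of bromo on an aromatic carbon. Going by the values given here, two measured steps bear on this. Putting a single aromatic ring on the same carbon gave a number 1.1 percentage points lower from compound 1 to compound 3 (within the scatter), a change inside the scatter. Putting a larger two-ring group there gave a number 18.4 percentage points higher from compound 1 to compound 2 (beyond the scatter), a modest rise, and the gap between these two groups shows as a number 19.5 percentage points lower from compound 2 to compound 3 (beyond the scatter). Since 2-fluorophenyl is a single six-membered ring of the same size as 4-fluorophenyl, the expected step in this assay is a number 0.7 percentage points higher from compound 1 to compound 4 (within the scatter), that is, no change beyond the scatter.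

Compound 4 is therefore estimated at 27%, with a likely range from 15% to 40%.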

Compound 4, a percentage reported as inhibition, at one concentration (the size of the read-out at that concentration, not a potency): 22.5%
For compound 4 the middle estimate is 4.5 percentage points above the measured one, and the stated range covers the measured number.
By their numbers in this assay, from the lowest: compounds 4, 3 and 1 (each within the scatter of the next); then compound 2.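

In this assay, 2-fluorophenyl in place of 4-fluorophenyl gives a number 2.7 percentage points lower from compound 3 to compound 4 (within the scatter) and so the fluorine's place on this single ring makes no readable difference between these two groups. Likewise, 2-fluorophenyl in place of bromo gives a number 3.8 percentage points lower from compound 1 to compound 4 (within the scatter) while 2-fluorophenyl in place of naphthalen-1-yl gives a number 22.2 percentage points lower from compound 2 to compound 4 (beyond the scatter) and this leaves naphthalen-1-yl as the only group shown here that stands clear of the others. No measurement given here explains why this group stands apart.

The compounds shown leave open whether an amine or a carboxylic acid on this aromatic carbon would move the number. They also leave open whether another two-ring group, such as naphthalen-2-yl or quinolin-8-yl, would match naphthalen-1-yl.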